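Branch and fluorine loss on the side chain

The source may report more compounds than this note shows. Statements on the series, on what has been measured and on what is new or still open speak of the compounds shown alone.

Compound 2 `Fc1cccc(CCC2(F)CCN(CCCc3c[nH]c4ccc(-n5cnnc5)cc34)CC2)c1` gives 22 nM in an assay on CHO cells for displacement of a labelled ligand from 5-hydroxytryptamine receptor 1B (Homo sapiens) (on this read-out lower numbers stand for stronger inhibition and higher numbers for weaker inhibition), and stands as the lower of the two numbers measured, the other being compound 1 `FC1(CCc2ccccc2)CCN(CCCc2c[nH]c3ccc(-n4cnnc4)cc23)CC1` with 49 nM in this assay. Compound 3 `CC(CC1(F)CCN(CCCc2c[nH]c3ccc(-n4cnnc4)cc23)CC1)c1ccccc1` has not been measured. It differs from compound 2 by 1-phenylethyl in place of 3-fluorobenzyl on a saturated chain carbon bound to a saturated ring carbon. Going by the values given here, the only measured step that bears on this, a 2.2-fold lower number from compound 1 to compound 2 (0.35 log units; beyond the scatter), concerns the fluorine alone, and compound 3 lacks that fluorine, so that step is expected to run backwards here. The added methyl branch on the chain has no measured counterpart among these compounds, so its effect is unknown. Compound 3 is therefore expected to give a modestly higher number than compound 2, about a 2.0-fold higher number from compound 2 to compound 3 (0.31 log units; beyond the scatter), with the branch left as an open uncertainty. The estimate for compound 3 in this assay is 45 nM, within a range from 15 nM to 135 nM.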

Compound 3, half-maximal inhibitory concentration: 28 nM
Compound 3: middle estimate off by 1.6-fold (0.21 log units), on the high side; the range from low to high includes it.
By their numbers in this assay, from the lowest: compounds 2, 3 and 1 (each within the scatter of the next, the first and the last beyond it).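

Going by these compounds alone, the methyl branch, the one feature with no earlier counterpart, turns out to be a small change in this assay: adding methyl on a saturated chain carbon bound to an aromatic carbon and a saturated chain carbon gives a 1.8-fold lower number from compound 1 to compound 3 (0.24 log units; within the scatter). Exchanging 3-fluorobenzyl for 1-phenylethyl, which removes the fluorine and adds the branch in one move, gives a 1.3-fold higher number from compound 2 to compound 3 (0.10 log units; within the scatter), so this position accepts both changes without a step beyond the scatter, and compound 3 sits within the scatter of both earlier compounds. Nothing at hand explains this result.

On these data alone, whether an ethyl or a hydroxyl group on that same chain carbon would stay as close remains open. So does the outcome of carrying the methyl branch and the aromatic fluorine together on one compound.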